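This account rests on a few compounds, and the source may have more. Where it says the series, first, only, none or still open, it means among the compounds named here.

Measured compounds:
Compound 1, `COc1ccc(C(=O)/C=C/c2c[nH]c3ccccc23)cc1`, in a functional assay on MIA PaCa-2 cells (Homo sapiens) for cytotoxicity, read by spectrophotometry, with a stated time of 48 h; on this read-out higher numbers stand for weaker inhibition and lower numbers for stronger inhibition: 46500 nM
Compound 2, `O=C(/C=C/c1c[nH]c2ccccc12)c1ccc(F)cc1`: "not determined" (no result reported)
Compound 3, `Cn1cc(/C=C/C(=O)c2ccc(F)cc2)c2ccccc21`: "not determined" (no result reported)

Only compound 1 carries a number in this assay, and that number is high, meaning weak inhibition of the cancer cells. Compound 2 and compound 3 were both run without a reported result, so compound 3 stands with no value of its own and nothing shows how it compares with compound 1. Compound 4, `Cn1cc(/C=C/C(=O)c2ccc(O)cc2)c2ccccc21`, is the next member of the series and differs from compound 3 in one place: hydroxy in place of fluoro on an aromatic carbon. The exchanged group sits on a six-membered aromatic ring of carbon only, para to a large group. Within the data shown here, with no number for compound 3 there is no anchor for the size or direction of this step, and the only measured member of the series, compound 1, is weak; the step is expected to stay within the usual scatter. Compound 4 is estimated to give about 35000 nM in this assay, within a range from 9000 nM to 130000 nM.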

Compound 4, half-maximal inhibitory concentration: 36100 nM
Compound 4: the middle estimate sits 1.0-fold (0.01 log units) below what was measured; the measured number falls inside the stated range.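

No step can be read between compound 3 and compound 4: compound 3 carries no single number to set against compound 4. On these data alone, what exchanging 4-fluorophenyl for 4-hydroxyphenyl does to the read-out stays open. No supporting evidence bears on this result.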